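This account rests on a few compounds, and the source may have more. Where it says the series, first, only, none or still open, it means among the compounds named here.

Measured so far:
compound 1 `CCCCCCCCc1cc2cn(COCCO)c(O)nc-2n1` — 65000 nM
compound 2 `CCCCc1cc2cn(COCCO)c(O)nc-2n1` — > 200000 nM
compound 3 `CCCCCC#Cc1cc2cn(COCCO)c(=O)nc2o1` — > 50000 nM

In a functional assay on HEL cells (Homo sapiens) (a lower number here means that less compound is tolerated, a higher number that more compound is tolerated), compound 1 gives 65000 nM. For compound 2 this assay reports only a limit, > 200000 nM. For compound 3 this assay likewise reports only a limit, > 50000 nM. The change butyl in place of hydrogen on a saturated chain carbon, four bonds along the chain from an aromatic carbon gives an at least 3.0-fold lower number from compound 2 to compound 1 (0.48 log units; beyond the scatter), a bound that rests on (the limit of > 200000 nM in this assay, at which 1 of the 3 values shown sits). Compound 4 `CCCCCCCCCC#Cc1cc2cn(COCCO)c(=O)nc2o1` is not yet measured; it carries butyl in place of hydrogen on a saturated chain carbon, five bonds along the chain from a triple-bonded carbon. The difference between the core of compound 3 and the core of compound 2 is not broken down here, and the place of the entering butyl differs: four bonds along the chain from an aromatic carbon in compound 1, five bonds along the chain from a triple-bonded carbon in compound 4, so this is the same kind of change, not the same change. From compound 3, which sits at the limit of > 50000 nM in this assay, at which 1 of the 3 values shown sits, a step of similar size is expected, an at least 1.6-fold lower number from compound 3 to compound 4 (0.22 log units; that floor lies within the scatter). Compound 4 is estimated at 30000 nM.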

Compound 4, half-maximal cytotoxic concentration: > 50000 nM
Compound 4 was reported as a limit; the forecaster's own chance of this, stated with the estimate: 30%; middle value at least 1.6-fold (0.22 log units) from the limit.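

Going by these compounds alone, compound 3 and compound 4 are both reported only as limits, so no step between them can be read. The compounds shown leave open whether the butyl entering in compound 4 changes the half-maximal cytotoxic concentration, and in which direction.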